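A few compounds are considered here, and "the series" means these few. Any claim that something is new, unique, unknown or untested is made for them only; others in the source may bear on it.

Working notes on the series, read in a functional assay on the whole organism for antagonist activity, with Mus musculus as the target; on this read-out lower numbers stand for an effect already at smaller amounts and higher numbers for an effect only at larger amounts of compound. Compound 1 `Cn1c(-c2cccc(F)c2)nnc1S(C)(=O)=O` gives > 200 mg/kg, which is a limit of the assay and not a number. It therefore stands at the limit of > 200 mg/kg in this assay, at which 2 of the 3 values shown sit. Compound 2 `Cn1c(-c2ccccc2)nnc1S(C)(=O)=O` gives 55 mg/kg as a true number. Among the compounds with values here, the only measured step, an at least 3.6-fold lower number from compound 1 to compound 2 (0.56 log units; beyond the scatter), is hydrogen in place of fluoro on an aromatic carbon. It shows that a single change can bring this series off the limit, but it concerns a different place from the one at issue here. Compound 3 `CSc1nnc(-c2ccc(Cl)cc2)n1C` already carries methylsulfanyl, with another substituent on the aromatic ring, and gives > 200 mg/kg, again a limit of the assay, which argues against a large step.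

Next is compound 4 `CSc1nnc(-c2cccc(F)c2)n1C`: methylsulfanyl in place of methylsulfonyl on an aromatic carbon. Within the data shown here, no measured step covers this exchange directly, so the expectation is weakly founded. The expected step is an at least 1.8-fold lower number from compound 1 to compound 4 (0.25 log units; that floor lies within the scatter), modest and toward lower numbers, and a second reading at the limit remains quite possible. For compound 4 the estimated value is 110 mg/kg. The expected range for compound 4 runs from 30 mg/kg to 250 mg/kg.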

Compound 4, dose for half-maximal effect: > 200 mg/kg
Compound 4: a limit, no number; the forecaster's own chance of this, stated with the estimate: 40%; at least 1.8-fold (0.25 log units) between middle value and limit.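

Compound 1 and compound 4 both give a limit of the assay and not a number, so no step can be read between them, because the exchange of methylsulfonyl for methylsulfanyl starts and ends at that limit: the limit of > 200 mg/kg in this assay, at which 3 of the 4 values shown sit.

The compounds shown leave open whether this exchange changes the read-out at all, in either direction, including on the unfluorinated aromatic ring of compound 2.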